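Removing the hydroxylated tail of compound 3

A few compounds are considered here, and "the series" means these few. Any claim that something is new, unique, unknown or untested is made for them only; others in the source may bear on it.

Within the data shown here, compound 3 `COC1=C(OC)[C@H](O)[C@H](C/C=C(\C)CC/C=C(\C)C[C@H](O)/C=C(\C)CO)[C@@H](C)C1=O` is one of three compounds measured in a functional assay on PC-3 cells (Homo sapiens) for inhibition, read by sulforhodamine B assay, with a stated time of 48 h; on this read-out higher numbers stand for weaker inhibition of growth and lower numbers for stronger inhibition of growth. In this assay compound 3 gives only a limit, > 30000 nM. Compound 2 `COC1=C(OC)[C@H](O)[C@H](C/C=C(\C)CC/C=C(\C)C[C@@H]2C[C@@H](C)C(=O)O2)[C@@H](C)C1=O` also gives only a limit, > 30000 nM. Compound 1 `COC1=C[C@H](O)[C@H](C/C=C(\C)CC/C=C(\C)CCC=C(C)C)[C@@H](C)C1=O` likewise gives only a limit, > 30000 nM. All three values sit at the limit of > 30000 nM in this assay, at which 3 of the 3 values shown sit, so compound 3 cannot be ranked against the others, and the step that the two limits leave unreadable from compound 2 to compound 3 cannot be read. Compound 4 `COC1=C(OC)[C@H](O)[C@H](C/C=C(\C)CC/C=C(\C)CCC=C(C)C)[C@@H](C)C1=O` differs from compound 3 by a group of 5 heavy atoms (5 carbon; no ring) in place of a group of 7 heavy atoms (5 carbon, 2 oxygen; no ring), on a saturated chain carbon bound to a double-bonded chain carbon. Compound 1 carries the same 3-methylbut-2-en-1-yl group on a different core, and its value is a limit. For compound 4 the expected step is therefore a step that the limit leaves unreadable from compound 3 to compound 4, nothing beyond the scatter. Compound 4 is expected to stay at the limit, estimated at 40000 nM within a range from 15000 nM to 150000 nM.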

Compound 4, concentration for 50% growth inhibition: 13500 nM
The estimate for compound 4 lay 3.0-fold (0.47 log units) above the measured number; the measured number lies below the stated range.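

Among these compounds, the 3-methylbut-2-en-1-yl group in place of the hydroxylated tail brings the first number in this assay that is not a limit, with an at least 2.2-fold lower number from compound 3 to compound 4 (0.34 log units; beyond the scatter). The same group in place of the lactone-bearing tail gives an at least 2.2-fold lower number from compound 2 to compound 4 (0.34 log units; beyond the scatter), and methoxy in place of hydrogen on a double-bonded ring carbon gives an at least 2.2-fold lower number from compound 1 to compound 4 (0.34 log units; beyond the scatter). All three steps are minimum sizes, because one end of each is a limit: the limit of > 30000 nM in this assay, at which 3 of the 4 values shown sit.

The compounds shown leave open how the number responds to a longer chain or a terminal amine at this place. They also leave open whether a carboxylic acid there would be tolerated.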